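Neopentyl in place of tert-butyl

The source may hold more compounds than are shown below. What is called first, only, known or untested is meant among the compounds shown, and "the series" means these compounds.

Compound 1 `Cc1cccc([C@@H](O)C(=O)N2N=CC[C@H]2C(=O)NCc2cc(Cl)ccc2-n2cnnn2)c1` reads < 12 mL.min-1.g-1 (a limit).
Compound 2 `CC(C)(C)[C@@H](O)C(=O)N1C[C@@H]2C[C@@H]2[C@H]1C(=O)NCc1cc(Cl)ccc1-n1cnnn1` reads < 15 mL.min-1.g-1 (a limit).

In an ADME assay on liver for metabolic stability, with Liver microsome (Homo sapiens) as the target, read by LC-MS, using microsomes (on this read-out lower numbers stand for slow clearance and higher numbers for fast clearance), both readings are limits of the assay, not exact numbers. Compound 2 therefore stands at a limit (< 15 mL.min-1.g-1) with no exact value. Compound 3 `CC(C)(C)C[C@@H](O)C(=O)N1C[C@@H]2C[C@@H]2[C@H]1C(=O)NCc1cc(Cl)ccc1-n1cnnn1` carries neopentyl in place of tert-butyl on a saturated chain carbon bound to a carbonyl carbon and an oxygen on a saturated carbon. Within the data shown here, no measured pair shows this change, so only a small upward step in this assay is expected (an at least 1.2-fold higher number from compound 2 to compound 3 (0.07 log units; that floor lies within the scatter)). For compound 3 the estimate is 18 mL.min-1.g-1 within an expected range (8 mL.min-1.g-1 to 40 mL.min-1.g-1).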

Compound 3, intrinsic clearance in microsomes: 20 mL.min-1.g-1
Compound 3: middle estimate off by 1.1-fold (0.05 log units), on the low side; the measured number falls inside the stated range.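

Among these compounds, compound 3 gives the first exact reading at this place in this assay and, with neopentyl in place of tert-butyl, the series shows an at least 1.3-fold higher number from compound 2 to compound 3 (0.12 log units; that floor lies within the scatter) for this change. Compound 2 reads as a limit, so only a floor can be stated and the true step may be larger: the limit of < 15 mL.min-1.g-1 in this assay, at which 1 of the 3 values shown sits. That floor alone shows no real rise, and it does not rule one out. Going by these compounds, how a longer chain, an amine or a carboxylic acid at this place would read in this assay stays open.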